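This account rests on a few compounds, and the source may have more. Where it says the series, first, only, none or still open, it means among the compounds named here.

Measured compounds:
compound 1, `CN(C)CCNC(=O)c1c(O)c2cccnc2n(-c2ccccc2)c1=O`, gives 18.4%
compound 2, `O=C(NC1CCN(Cc2ccccc2)CC1)c1c(O)c2cccnc2n(-c2ccccc2)c1=O`, gives 1.2%

Both compounds were tested in a functional assay on the whole organism for inhibition, with Rattus norvegicus as the target, read by cytopathic effect and paw edema, at a dose of 100 mg/kg by the oral route; on this read-out higher numbers stand for more inhibition at the one dose given (going by the name of the read-out) and lower numbers for less inhibition. In this assay compound 1 gives 18.4%, which is the higher of the two numbers recorded. Compound 2 gives 1.2% in this assay, and the gap between the two lies beyond the usual scatter, so compound 1 stands clearly above compound 2 on the numbers available. The two compounds share the same core and differ only in the group attached to the amide nitrogen.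

Compound 3, `COc1cccc(NC(=O)c2c(O)c3cccnc3n(-c3ccccc3)c2=O)c1`, has not yet been measured in this assay. It differs from compound 1 in one place: 3-methoxyphenyl in place of 2-(dimethylamino)ethyl on an amide-type nitrogen. Among the measured compounds shown here, no step between two measured compounds matches this particular change, so there is no direct guide to its size. Given that compound 1 gives 18.4% and compound 2 gives 1.2%, both values are modest, and the change is expected to move the number only a little, with a small drop toward a step of a number 6.4 percentage points lower from compound 1 to compound 3 (within the scatter) that likely stays within the scatter. Compound 3 is therefore estimated to give 12%, with a plausible range from 0% to 32%.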

Compound 3, a percentage reported as inhibition, in the whole organism at one dose (the size of the read-out at that dose, not a potency): 20.7%
Estimate against measurement, compound 3: 8.7 percentage points below; the measured number falls inside the stated range.
By their numbers in this assay, from the lowest: compound 2; then compounds 1 and 3 (each within the scatter of the next).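

In this assay, the swap of 3-methoxyphenyl for 2-(dimethylamino)ethyl on the amide-type nitrogen gives a number 2.3 percentage points higher from compound 1 to compound 3 (within the scatter), so this read-out does not separate the two groups. Among the compounds shown here, this is the first step that can be read at this position, and it shows that, for this pair, an open chain containing an amine nitrogen and a six-membered aromatic ring of carbon only can replace each other with no change beyond the scatter, even though the two groups differ in shape and in atoms. Nothing available explains why these two different groups give numbers this close.

The compounds shown leave open what the ring and its methoxy group each contribute, and a plain phenyl on the amide-type nitrogen would separate the two. They also leave open whether any group at this position can lift the number well clear of the scatter, a question that a carboxylic acid or a longer chain ending in an amine could begin to answer.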